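A few compounds are considered here, and "the series" means these few. Any claim that something is new, unique, unknown or untested is made for them only; others in the source may bear on it.

Compound 1 `COc1ncnc2c1c(-c1ccoc1)cn2[C@@H]1O[C@H](CO)[C@@H](O)[C@H]1O` gives 150 nM in a functional assay on HL-60 cells (Homo sapiens) for antiproliferative activity, read by XTT assay, with a stated time of 72 h; a lower number here means a stronger inhibitor, a higher number a weaker inhibitor. Compound 3 `CSc1ncnc2c1c(-c1ccoc1)cn2[C@@H]1O[C@H](CO)[C@@H](O)[C@H]1O` gives 360 nM. Compound 2 `COc1nc(N)nc2c1c(-c1ccoc1)cn2[C@@H]1O[C@H](CO)[C@@H](O)[C@H]1O` gives only a limit, > 20000 nM.

Compound 1 stands lowest of the two numbers shown, and compound 3 is the nearest, with a 2.4-fold higher number from compound 1 to compound 3 (0.38 log units; beyond the scatter). For compound 2 the result is a limit, (the limit of > 20000 nM in this assay, at which 1 of the 3 values shown sits), not a number.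

Compound 4 `COc1ncnc2c1c(-c1ccco1)cn2[C@@H]1O[C@H](CO)[C@@H](O)[C@H]1O` is not yet measured. It differs from compound 1 by furan-2-yl in place of furan-3-yl on an aromatic carbon. Neither measured step bears on this change: an at least 130-fold higher number from compound 1 to compound 2 (2.12 log units; beyond the scatter) concerns an amino group and a 2.4-fold higher number from compound 1 to compound 3 (0.38 log units; beyond the scatter) concerns a methylsulfanyl group, while the furan ring is untouched in both. Within the data shown here, with no step to lean on, the expectation is a shift within or only modestly beyond the scatter, a 1.7-fold higher number from compound 1 to compound 4 (0.22 log units; within the scatter). Compound 4 is therefore estimated at 250 nM, within 80 nM to 1000 nM.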

Compound 4, half-maximal inhibitory concentration: 100 nM
Estimate against measurement, compound 4: 2.5-fold (0.40 log units) above; the range from low to high includes it.
By their numbers in this assay, from the lowest: compounds 4 and 1 (each within the scatter of the next); then compound 3. At a limit, above all of these: compound 2.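

In this assay, among these compounds, the earlier compounds changed only other parts of the molecule, while this pair changes how the furan is attached, giving a 1.5-fold lower number from compound 1 to compound 4 (0.18 log units; within the scatter). So furan-2-yl and furan-3-yl cannot be told apart at this position, and the exact attachment of the furan matters little in this assay. Nothing measured here accounts for this result. As far as these compounds go, what a phenyl ring or an amine would do at this position stays open. So does whether furan-2-yl would give the same result alongside methylsulfanyl in place of methoxy.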